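The source may report more compounds than this note shows. Statements on the series, on what has been measured and on what is new or still open speak of the compounds shown alone.

Going by the values given here, compound 3 `COc1ccc(-c2cn3cc(C4=CCN(S(=O)(=O)C5CCCC5)CC4)ccc3n2)cc1OC` gives 6470 nM in a functional assay on A549 cells (Homo sapiens) for antiproliferative activity, read by MTT assay, with a stated time of 48 h (a higher number here means a weaker inhibitor, a lower number a stronger inhibitor), and carries the highest number of the three measured members. Its nearest neighbour is compound 2 `COc1ccc(-c2cn3cc(C4=CCN(S(=O)(=O)C5CCCCC5)CC4)ccc3n2)cc1OC`, which gives 4490 nM; the two lie within the scatter of each other, as a 1.4-fold higher number from compound 2 to compound 3 (0.16 log units; within the scatter) shows. The furthest is compound 1 `COc1ccc(-c2cn3cc(C4=CCN(C(=O)c5ccccc5C(F)(F)F)CC4)ccc3n2)cc1OC`, which gives 2550 nM; here the gap is beyond the scatter, see a 2.5-fold higher number from compound 1 to compound 3 (0.40 log units; beyond the scatter).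

Compound 4 `COc1ccc(-c2cn3cc(C4=CCN(C(=O)c5cccc(C(F)(F)F)c5)CC4)ccc3n2)cc1OC` differs from compound 3 in one place: (3-(trifluoromethyl)phenyl)carbonyl in place of cyclopentylsulfonyl on an amine nitrogen in a ring. The measured step that bears most directly on this exchange is the reverse of a 2.5-fold higher number from compound 1 to compound 3 (0.40 log units; beyond the scatter), where a (2-(trifluoromethyl)phenyl)carbonyl group in place of cyclopentylsulfonyl gave the lower number. The step of a 1.8-fold higher number from compound 1 to compound 2 (0.25 log units; within the scatter), within the scatter, adds little. Compound 4 carries the trifluoromethyl at a different ring position than compound 1, for which no measured comparison exists, so the step is taken as similar in size and direction to the return from compound 3 to compound 1, with added uncertainty. Compound 4 is therefore expected to give about 2500 nM in this assay, with a range from 900 nM to 7000 nM. The expected step is a 2.6-fold lower number from compound 3 to compound 4 (0.41 log units; beyond the scatter).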

Compound 4, half-maximal inhibitory concentration: 3690 nM
Beside the measured number, compound 4's estimate is 1.5-fold (0.17 log units) below it; measured number inside the range.
By their numbers in this assay, from the lowest: compounds 1, 4, 2 and 3 (each within the scatter of the next, the first and the last beyond it).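

In this assay, 3-(trifluoromethyl)phenyl in place of 2-(trifluoromethyl)phenyl on the carbonyl carbon gives a change within the scatter (a 1.4-fold higher number from compound 1 to compound 4 (0.16 log units; within the scatter)), the first measured read on where the trifluoromethyl sits in this series. Compound 4 also stays within the scatter of both sulfonyl compounds (a 1.8-fold lower number from compound 3 to compound 4 (0.24 log units; within the scatter); a 1.2-fold lower number from compound 2 to compound 4 (0.09 log units; within the scatter)), so the gap beyond the scatter between compound 1 and compound 3 does not reappear with this carbonyl group, and the sulfonyl and carbonyl links are not separated here. No measurement at hand accounts for these steps.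

Still open, on these data alone, is whether a nitrile or a chlorine in place of the trifluoromethyl on the phenyl ring would shift the number beyond the scatter. Equally open, as far as these compounds go, is what a free amine at that ring nitrogen, without any carbonyl or sulfonyl group, would give in this assay.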